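Sulfonyl aryl swap on a piperazine core: half-life outlook

This account rests on a few compounds, and the source may have more. Where it says the series, first, only, none or still open, it means among the compounds named here.

Measured compounds:
compound 1, `O=C(NCc1ccc(F)cc1)c1ccc(N2CCN(S(=O)(=O)c3cccnc3O)CC2)nn1`, 1.2 h
compound 2, `Cc1cc(F)ccc1S(=O)(=O)N1CCN(c2ccc(C(=O)NCc3ccc(F)cc3)nn2)CC1`, 0.25 h
compound 3, `Cc1nc(C(F)(F)F)ccc1S(=O)(=O)N1CCN(c2ccc(C(=O)NCc3ccc(F)cc3)nn2)CC1`, 0.383 h

In an ADME assay on microsomes from liver (Mus musculus) for metabolic stability, read by LC-MS, using NADPH, tested at 10 uM (on this read-out lower numbers stand for a shorter-lived compound and higher numbers for a longer-lived compound), compound 3 gives 0.383 h, the second highest of the three numbers. Compound 2 lies within the scatter of compound 3, as a 1.5-fold higher number from compound 2 to compound 3 (0.19 log units; within the scatter) shows, while compound 1 stands clearly higher, as a 3.1-fold lower number from compound 1 to compound 3 (0.50 log units; beyond the scatter) shows. Compound 4, `Nc1ncccc1S(=O)(=O)N1CCN(c2ccc(C(=O)NCc3ccc(F)cc3)nn2)CC1`, differs from compound 3 only at the sulfonyl sulfur: 2-aminopyridin-3-yl in place of 2-methyl-6-(trifluoromethyl)pyridin-3-yl on a sulfonyl sulfur. For the measured compounds named here, the steps that bear on this change are those leaving the 2-hydroxypyridin-3-yl group of compound 1, namely a 4.8-fold lower number from compound 1 to compound 2 (0.68 log units; beyond the scatter) and a 3.1-fold lower number from compound 1 to compound 3 (0.50 log units; beyond the scatter), both beyond the scatter. The entering 2-aminopyridin-3-yl group, like the 2-hydroxypyridin-3-yl group of compound 1, brings one hydrogen-bond donor and two acceptors, whereas the leaving group brings none and one. Going by the values given here, a rise beyond the scatter in this assay is therefore expected, though with only three compounds its size is uncertain. Compound 4 is expected to give 0.9 h, with a range from 0.4 h to 2 h. The expected step is a 2.3-fold higher number from compound 3 to compound 4 (0.37 log units; beyond the scatter).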

Compound 4, half-life: 0.317 h
The estimate for compound 4 lay 2.8-fold (0.45 log units) above the measured number; measured number below the stated range.
By their numbers in this assay, from the lowest: compounds 2, 4 and 3 (each within the scatter of the next); then compound 1.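

In this assay, the 2-aminopyridin-3-yl group of compound 4 does not separate from the two sulfonyl groups without a hydrogen-bond donor: the change reads as a 1.2-fold lower number from compound 3 to compound 4 (0.08 log units; within the scatter) and as a 1.3-fold higher number from compound 2 to compound 4 (0.10 log units; within the scatter). Sharing its donor and acceptor counts with the 2-hydroxypyridin-3-yl group is therefore not enough here, since amino in place of hydroxy on an aromatic carbon gives a 3.8-fold lower number from compound 1 to compound 4 (0.58 log units; beyond the scatter). Among these four compounds, compound 1 alone stands apart at this position on the sulfonyl sulfur, and the counts do not sort the other three from it.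

Nothing available bears on what lies behind this difference. On these data alone, whether a 2-methoxypyridin-3-yl group on the sulfonyl sulfur would stand with compound 1 or with the other three remains open.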